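A few compounds are considered here, and "the series" means these few. Any claim that something is new, unique, unknown or untested is made for them only; others in the source may bear on it.

Compound 2 `C=CCCn1cnc2c1c(=O)n(C)c(=O)n2CCC` is measured in an assay on Cerebral cortex for binding affinity to adenosine receptor A1 (Cavia porcellus), read by radioligand binding (a lower number here means a stronger inhibitor, a higher number a weaker inhibitor), where compound 2 gives 6000 nM. Within the data shown here, that is the only number among the values shown. The other value is a limit of the assay: compound 1 `CCCn1c(=O)n(CC(=O)O)c(=O)c2[nH]cnc21` gives > 200000 nM in this assay, which is a limit and not a number, as noted in the limit of > 200000 nM in this assay, at which 1 of the 2 values shown sits. Between compound 1 and compound 2 no step is set out, so only their two values can be read side by side.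

Compound 3 `CCCn1c(=O)n(C)c(=O)c2c1ncn2CCC#N` has not yet been measured in this assay. It differs from compound 2 in one place: cyano in place of vinyl on a saturated chain carbon, two bonds along the chain from an aromatic nitrogen. Among the measured compounds shown here, with no measured step of this kind available, the author expects a modest loss of affinity, the step of a 2.5-fold higher number from compound 2 to compound 3 (0.40 log units; beyond the scatter), somewhat beyond the scatter. Compound 3 is therefore estimated at 15000 nM, with a range from 4000 nM to 60000 nM.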

Compound 3, inhibition constant: 88600 nM
Beside the measured number, compound 3's estimate is 5.9-fold (0.77 log units) below it, and the stated range ends below it.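

Among these compounds, earlier, the values offered no step at this position; now, in this assay, cyano in place of vinyl on a saturated chain carbon, two bonds along the chain from an aromatic nitrogen, gives a 15-fold higher number from compound 2 to compound 3 (1.17 log units; beyond the scatter), a large change beyond the scatter. Vinyl and cyano have the same count of heavy atoms, so this position separates two groups of equal heavy-atom count, which differ in that cyano brings a triple bond and a hydrogen-bond acceptor. Nothing in the data shown gives a reason for this step.

The compounds shown leave open whether the loss belongs to the nitrile itself or would also appear with another chain end, such as a hydroxyl or an amine. They also leave open how a longer chain ending in vinyl or cyano would read at this position.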